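The source may report more compounds than this note shows. Statements on the series, on what has been measured and on what is new or still open speak of the compounds shown alone.

Working notes on the series

In an ADME assay on PC-3 cells (Homo sapiens) for cytotoxicity, read by WST assay, tested at 100 uM (a lower number here means less inhibition, a higher number more inhibition at the concentration tested (going by the name of the read-out)), compound 3 `COCc1cccc(C(=O)N2CCCC(C(=O)Nc3ccc(Cl)cc3)C2)c1` gives 0%. Among the measured compounds shown here, compound 3 sits level with the two other members measured so far: compound 1 `Cc1cccc(C(=O)N2CCCC(C(=O)Nc3ccc(Cl)cc3)C2)c1` gives 0%, and compound 2 `CSc1cccc(C(=O)N2CCCC(C(=O)Nc3ccc(Cl)cc3)C2)c1` gives 0%. All three steps among them are flat: no change at the digits printed from compound 1 to compound 2 (within the scatter), no change at the digits printed from compound 1 to compound 3 (within the scatter), and no change at the digits printed from compound 2 to compound 3 (within the scatter). Across the three, variation of the substituent on the aromatic ring that carries the amide to the shared core has not moved the read-out at all.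

Compound 4 `O=C(Nc1ccc(Cl)cc1)C1CCCN(C(=O)c2cccc(-c3cnco3)c2)C1` is the next member. Its difference from compound 3 is 1,3-oxazol-5-yl in place of methoxymethyl on an aromatic carbon. For the measured compounds named here, the steps that bear on it are the two that replace a group at that same ring position, and both were flat; none of the measured steps brings in an aromatic ring, so the new group has no direct precedent here. On the evidence of the three flat steps, no change beyond the scatter is expected, and the step this expectation means is no change at the digits printed from compound 3 to compound 4 (within the scatter). Compound 4 is expected to give 0%, with a range from -5% to 15%.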

Compound 4, a percentage reported as inhibition, at one concentration (the size of the read-out at that concentration, not a potency): 0%
Compound 4: the middle estimate sits on the measured number at the digits printed; the measured number falls inside the stated range.
By their numbers in this assay, from the lowest: compounds 1, 2, 3 and 4 (each within the scatter of the next).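

The read-out shows no change at the digits printed from compound 3 to compound 4 (within the scatter) and no change at the digits printed from compound 2 to compound 4 (within the scatter) and no change at the digits printed from compound 1 to compound 4 (within the scatter) in this assay at this ring position. Among the compounds shown here, the flat result at this position now reaches beyond methyl, methylsulfanyl and methoxymethyl to 1,3-oxazol-5-yl, the first group here that carries a ring of its own, a five-membered aromatic ring with 2 hetero atoms. Nothing available bears on why the read-out stays level across these changes.

Open, as far as these compounds go, is whether an amine, a carboxylic acid or a longer chain on this aromatic carbon would lift the read-out from the level shared by these four compounds. Also open, from the compounds shown here alone, is whether any change elsewhere on the shared core would move it, since all four differ only at this one place.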